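The compounds below may be only part of what the source reports. "The series", "measured", "known", "first", "only" and "open" are said of these compounds alone.

Of the compounds shown here, three sharing one core have been tested in an ADME assay on BJ cells (Homo sapiens) for cytotoxicity, with a stated time of 72 h; a higher number here means that more compound is needed for the effect, a lower number that less compound is needed. Compound 1 `Cc1cc(NC(=O)Nc2ccc([N+](=O)[O-])c(C(F)(F)F)c2)c2ccccc2n1` reaches only the limit of the assay, giving > 25000 nM. Compound 2 `Cc1cc(NC(=O)Nc2ncccc2C)c2ccccc2n1` also stops at a limit, > 25000 nM. Compound 3 `Cc1cc(NC(=O)Nc2cccc(Cl)c2)c2ccccc2n1` likewise gives a limit, > 25000 nM. Compound 3 therefore stands where every measured value sits: the limit of > 25000 nM in this assay, at which 3 of the 3 values shown sit. Among the measured compounds shown here, the only step between measured compounds, a step that the two limits leave unreadable from compound 2 to compound 3, cannot be read. Compound 4 `Cc1cc(NC(=O)Nc2cccc(C(F)(F)F)c2)c2ccccc2n1` differs from compound 3 by trifluoromethyl in place of chloro on an aromatic carbon. For the measured compounds named here, no measured step speaks to a change of this kind, and the limits leave no direction to read, so no step beyond the scatter is expected in this assay. Compound 4 is therefore estimated at 35000 nM, within 15000 nM to 100000 nM, an expected step that the limit leaves unreadable from compound 3 to compound 4.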

Compound 4, half-maximal effective concentration: > 25000 nM
Compound 4: only a limit was reported (the forecaster's own chance of this, stated with the estimate: 80%); the middle value lies beyond the limit too.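

The steps from compound 3 and from compound 1 to compound 4 cannot be read, because compound 4 also gives only a limit: the limit of > 25000 nM in this assay, at which 4 of the 4 values shown sit.
Whether any of these compounds truly differs from another in this assay stays open.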